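This account rests on a few compounds, and the source may have more. Where it says the series, first, only, none or still open, it means among the compounds named here.

Of the compounds shown here, three sharing one core have been measured in an assay on isolated protein for inhibition of serine/threonine-protein kinase PAK 4 (Homo sapiens), read by HTRF, with a stated time of 60 min; on this read-out higher numbers stand for weaker inhibition and lower numbers for stronger inhibition. Compound 1 `Cc1cc(Nc2nc(NC3CCNC3)nc3[nH]ncc23)n[nH]1` gives 1050 nM. Compound 2 `Cc1cc(Nc2nc(NCc3ccccc3)nc3[nH]ncc23)n[nH]1`, which carries a benzyl group in place of the pyrrolidin-3-yl group on the ring nitrogen, gives 1960 nM, and the step of a 1.9-fold higher number from compound 1 to compound 2 (0.27 log units; within the scatter) stays within the scatter. Compound 3 `Cc1cc(Nc2nc(NCc3ccccc3F)nc3[nH]ncc23)n[nH]1`, with a 2-fluorobenzyl group at the same nitrogen, gives 389 nM. Compound 3 stands lowest of the three: the step of a 2.7-fold lower number from compound 1 to compound 3 (0.43 log units; beyond the scatter) and the step of a 5.0-fold lower number from compound 2 to compound 3 (0.70 log units; beyond the scatter) both lie beyond the scatter, so on these numbers compound 3 is the strongest inhibitor of the set.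

Compound 4 `Cc1cc(Nc2nc(NCc3ccccc3Br)nc3[nH]ncc23)n[nH]1` is not yet measured. It differs from compound 3 by bromo in place of fluoro on an aromatic carbon. Among the compounds with values here, only one measured step touches this position: the step of a 5.0-fold lower number from compound 2 to compound 3 (0.70 log units; beyond the scatter), in which a fluoro entered in place of hydrogen. Within the data shown here, no measured pair shows one halogen replaced by another, so that step gives only an indirect guide. Placing a bromo where the fluoro sat is expected to give a number close to that of compound 3, with a step of a 1.1-fold lower number from compound 3 to compound 4 (0.05 log units; within the scatter) that may well fall within the scatter. Compound 4 is therefore estimated at 350 nM in this assay, with a range from 120 nM to 1000 nM.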

Compound 4, half-maximal inhibitory concentration: 1090 nM
Beside the measured number, compound 4's estimate is 3.1-fold (0.49 log units) below it; the measured number lies above the stated range.
By their numbers in this assay, from the lowest: compound 3; then compounds 1, 4 and 2 (each within the scatter of the next).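

At this position the choice of halogen matters: bromo in place of fluoro, on an aromatic carbon ortho to a large group, gives a 2.8-fold higher number from compound 3 to compound 4 (0.45 log units; beyond the scatter) beyond the scatter, so the drop in the number seen on adding fluoro does not carry over to bromo. Measured against hydrogen, bromo shows no readable difference, as a 1.8-fold lower number from compound 2 to compound 4 (0.25 log units; within the scatter) stays within the scatter, and 2-bromobenzyl likewise cannot be told apart from pyrrolidin-3-yl on the nitrogen, with a 1.0-fold higher number from compound 1 to compound 4 (0.02 log units; within the scatter) also within the scatter. So among the three groups now seen in this place, only fluoro stands apart, and nothing in the data shown explains why fluoro and bromo differ here.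

The compounds shown leave open whether chloro, methyl or methoxy in this same place would read like fluoro or like bromo. They also leave open whether a benzyl carrying an amine or a carboxylic acid, or a longer chain in place of the benzyl on that nitrogen, would fall closer to compound 3 or to compound 4.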